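Taking the Last Methoxy Off a Weak Compound

A few compounds are considered here, and "the series" means these few. Any claim that something is new, unique, unknown or untested is made for them only; others in the source may bear on it.

In a functional assay on CCRF-CEM cells (Homo sapiens) for antiproliferative activity, read by cell counting, with a stated time of 2 days (a higher number here means a weaker inhibitor, a lower number a stronger inhibitor), compound 1 `COc1ccc(C(=O)c2sc(N3CCCC3)nc2N)cc1OC` gives 19000 nM as its value. Compound 2 `COc1cccc(C(=O)c2sc(N3CCCC3)nc2N)c1` shows > 200000 nM as a limit of the assay, not a number. Compound 3 `COc1ccccc1C(=O)c1sc(N2CCCC2)nc1N` at 171000 nM holds the higher of the two true numbers. The change to compound 4 `Nc1nc(N2CCCC2)sc1C(=O)c1ccccc1` is hydrogen in place of methoxy on an aromatic carbon in one place, hydrogen in place of methoxy on an aromatic carbon ortho to a large group. For the measured compounds named here, the one measured step of this kind (an at least 10-fold higher number from compound 1 to compound 2 (1.02 log units; beyond the scatter)) was large. That step ends on a limit (the limit of > 200000 nM in this assay, at which 1 of the 3 values shown sits) and starts from a different compound. A small rise is therefore expected in this assay (a 1.2-fold higher number from compound 3 to compound 4 (0.07 log units; within the scatter)) and it may stay within the scatter. The estimated value for compound 4 is 200000 nM with an expected range from 90000 nM to 400000 nM as its span.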

Compound 4, half-maximal inhibitory concentration: > 200000 nM
Compound 4: no number, only a limit (the forecaster's own chance of this, stated with the estimate: 60%); the middle value sits exactly at the limit.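

With the methoxy gone from the aromatic carbon ortho to a large group, the change gives an at least 1.1-fold higher number from compound 3 to compound 4 (0.06 log units; that floor lies within the scatter), so only a floor for this step is known, not its size. The same exchange can now be compared at two places in this assay: the same change on two cores in this assay, an at least 10-fold higher number (1.02 log units; beyond the scatter) from compound 1 to compound 2 and an at least 1.1-fold higher number (0.06 log units; that floor lies within the scatter) from compound 3 to compound 4; the limit leaves it open whether they differ The step between compound 2 and compound 4 cannot be read, as both stand at a limit rather than a number: the limit of > 200000 nM in this assay, at which 2 of the 4 values shown sit.

On these data alone, how far past that limit compound 4 lies remains open. Also open, as far as these compounds go, is whether an amine or a carboxylic acid on that aromatic carbon would give a readable number in this assay.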